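A few compounds are considered here, and "the series" means these few. Any claim that something is new, unique, unknown or untested is made for them only; others in the source may bear on it.

Compound 1, with the structure `O=C(CCCCC1CCSS1)NCc1cn(CCCCCOc2ccc3ccc(=O)oc3c2)nn1`, shows in a functional assay on PC-12 cells (Rattus norvegicus) for cytotoxicity, read by MTT assay, with stated times of 3 h and 2 h, tested at 1 uM (a higher number here means a stronger effect of the compound at the concentration tested, a lower number a weaker effect), a value of 57.2%. Within the data shown here, compound 2, with the structure `O=C(CCCCC1CCSS1)NCc1cn(CCCCCOc2ccc3cc(-c4ccc(Br)cc4)c(=O)oc3c2)nn1`, gives in this assay a value of 43.7%, which is the lower of the two numbers measured so far. Among the measured compounds shown here, the one measured step, a number 13.5 percentage points lower from compound 1 to compound 2 (beyond the scatter), is what separates these two compounds. Compound 3, with the structure `O=C(CCCCC1CCSS1)NCc1cn(CCCCCOc2ccc3cc(-c4ccc(Cl)c(Cl)c4)c(=O)oc3c2)nn1`, is the next compound to be measured. It differs from compound 2 in one place: 3,4-dichlorophenyl in place of 4-bromophenyl on an aromatic carbon. For the measured compounds named here, the only step available does not match this change closely, since it adds a 4-bromophenyl group where a hydrogen had been, whereas here one halogen-bearing phenyl group replaces another of nearly the same size. That step was modest, and exchanging one such group for another seems unlikely to move the number much, so a step within the scatter is expected, with compound 2 as the point of reference. The expected step of a number 1.7 percentage points lower from compound 2 to compound 3 (within the scatter) therefore stays small. For compound 3 an estimated value of 42% is expected, within a range from 30% to 55%.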

Compound 3, a percentage reported as activity, at one concentration (the size of the read-out at that concentration, not a potency): 50.6%
Compound 3: the middle estimate sits 8.6 percentage points below what was measured; the measured number falls inside the stated range.
By their numbers in this assay, from the lowest: compounds 2, 3 and 1 (each within the scatter of the next, the first and the last beyond it).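

In this assay, putting 3,4-dichlorophenyl in place of 4-bromophenyl on this aromatic carbon gives a number 6.9 percentage points higher from compound 2 to compound 3 (within the scatter), so the two halogen-bearing phenyl groups cannot be told apart here. Measured against hydrogen at the same carbon, 3,4-dichlorophenyl gives a number 6.6 percentage points lower from compound 1 to compound 3 (within the scatter), while 4-bromophenyl gives a number 13.5 percentage points lower from compound 1 to compound 2 (beyond the scatter), so a halogen-bearing phenyl group at this position does not always move the number beyond the scatter. Nothing available explains this difference between the two groups.

Going by these compounds, what an unsubstituted phenyl group, or a phenyl group carrying a methoxy group or an amine, would do at this carbon remains open, as does whether either would stay within the scatter of compound 1. Also open is the effect of a group of another kind at the same position, such as a carboxylic acid or a short alkyl chain, and whether the small gaps seen among these three compounds would hold at other concentrations.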